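Phenyl in Place of Pyridin-2-yl: Another Limit Expected

The source may report more compounds than this note shows. Statements on the series, on what has been measured and on what is new or still open speak of the compounds shown alone.

Compound 1 `C=C1C[C@]23C[C@@]1(O)CC[C@H]2c1ccc(O)c(C)c1[C@@H]3Cn1cc(-c2ccccn2)nn1` and compound 3 `C=C1C[C@]23C[C@@]1(O)CC[C@H]2c1ccc(O)c(C)c1[C@@H]3Cn1cc(-c2ccccc2)nn1` share one core, while compound 2 `C=C1C[C@]23C[C@@]1(O)CC[C@@H]2c1cccc(C)c1[C@@H]3Cn1cc(-c2ccccn2)nn1` is built on another; the difference between the two cores is not broken down here. Compound 4 `C=C1C[C@]23C[C@@]1(O)CC[C@@H]2c1cccc(C)c1[C@@H]3Cn1cc(-c2ccccc2)nn1` has not yet been measured. In a functional assay on SW480 cells (Homo sapiens) for cytotoxicity, read by MTT assay, with a stated time of 4 days (a lower number here means a stronger inhibitor, a higher number a weaker inhibitor), compound 1 gives only a limit of > 20000 nM. In this assay compound 3 also gives only a limit of > 20000 nM. Compound 2 likewise gives only a limit of > 20000 nM. The change from compound 1 to compound 3 is phenyl in place of pyridin-2-yl on an aromatic carbon, and its step that the two limits leave unreadable from compound 1 to compound 3 cannot be sized because of the limit of > 20000 nM in this assay, at which 3 of the 3 values shown sit.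

The same change, (phenyl in place of pyridin-2-yl on an aromatic carbon), leads from compound 2 to compound 4, at a place described in the same words. Compound 4 is therefore expected to make a step that the limit leaves unreadable from compound 2 to compound 4, resting on the earlier unreadable step from compound 1 to compound 3. For compound 4 the estimate in this assay is 30000 nM, expected between 10000 nM and 100000 nM, and most likely the assay will again report only a limit.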

Compound 4, half-maximal inhibitory concentration: > 20000 nM
Compound 4 ended at the assay's limit (the forecaster's own chance of this, stated with the estimate: 90%); the middle value is on the limit's open side.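

In this assay compound 4 gives only a limit, just as compound 2 does, so the phenyl-for-pyridin-2-yl change between compound 2 and compound 4 has no readable size, and no new step can be read: (the limit of > 20000 nM in this assay, at which 4 of the 4 values shown sit). The compounds shown leave open whether exchanging these two groups changes cytotoxicity at all.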